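The source may hold more compounds than are shown below. What is called first, only, known or untested is meant among the compounds shown, and "the series" means these compounds.

Three compounds sharing one core were tested in a functional assay on L1210 cells (Mus musculus) for inhibition, read by cell counting, with a stated time of 2 days; a lower number here means a stronger inhibitor, a higher number a weaker inhibitor. Compound 1 `C=C(Br)C(=O)Nc1cccc(-c2cn3nc(-c4ccc(F)cc4)sc3n2)c1` gives 250 nM. Compound 2 `C=C(Br)C(=O)Nc1cccc(-c2cn3nc(-c4ccc(Cl)cc4)sc3n2)c1` gives 1400 nM. Compound 3 `Nc1cccc(-c2cn3nc(-c4ccc(Cl)cc4)sc3n2)c1` gives only a limit of the assay, >= 250000 nM. The change from compound 2 to compound 1 is fluoro in place of chloro on an aromatic carbon, and it brought a 5.6-fold lower number from compound 2 to compound 1 (0.75 log units; beyond the scatter). The change from compound 2 to compound 3 is hydrogen in place of (1-bromoethenyl)carbonyl on a nitrogen on an aromatic ring, and it brought an at least 170-fold higher number from compound 2 to compound 3 (2.25 log units; beyond the scatter), that pair resting on (the limit of >= 250000 nM in this assay, at which 1 of the 3 values shown sits). Compound 4 `Nc1cccc(-c2cn3nc(-c4ccc(F)cc4)sc3n2)c1` has not yet been measured. It differs from compound 3 by fluoro in place of chloro on an aromatic carbon, the same change as that from compound 2 to compound 1. With the (1-bromoethenyl)carbonyl group present that change gave a modest step; compound 3, the starting point here, sits at a limit of the assay, and the 4-chlorophenyl to 4-fluorophenyl exchange is small beside the loss of that group. In this assay compound 4 is expected to give 250000 nM, most likely between 100000 nM and 1000000 nM. This expectation means a number no higher from compound 3 to compound 4 (the limit leaves the size open), essentially no change, and it rests on an at least 170-fold higher number from compound 2 to compound 3 (2.25 log units; beyond the scatter).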

Compound 4, half-maximal inhibitory concentration: >= 250000 nM
Compound 4 gave a limit, no number (the forecaster's own chance of this, stated with the estimate: 85%); the middle value sits exactly at the limit.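

In this assay compound 4 gives >= 250000 nM, which is a limit of the assay and not a number. Replacing the (1-bromoethenyl)carbonyl group on the nitrogen with hydrogen brings an at least 1000-fold higher number from compound 1 to compound 4 (3.00 log units; beyond the scatter), so the large loss seen with the chloro compounds also appears with the fluoro compounds, but this does not show that the loss is equal in size on the two cores: the same change on two cores in this assay, an at least 170-fold higher number (2.25 log units; beyond the scatter) from compound 2 to compound 3 and an at least 1000-fold higher number (3.00 log units; beyond the scatter) from compound 1 to compound 4; the limit leaves it open whether they differ The step from compound 3 to compound 4 cannot be read, so the data do not show whether fluoro in place of chloro has any effect once the (1-bromoethenyl)carbonyl group is gone: the limit of >= 250000 nM in this assay, at which 2 of the 4 values shown sit.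

The compounds shown leave open whether the bromine itself is needed, a question that an acryloyl or acetyl group on that nitrogen would address. Also open, on these data alone, is how a methyl group or a hydrogen in the place of the fluoro or chloro would compare when the (1-bromoethenyl)carbonyl group is present.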